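Extending the amide chain of compound 1

This account rests on a few compounds, and the source may have more. Where it says the series, first, only, none or still open, it means among the compounds named here.

Compound 1 `CCCCNC(=O)C1C(C(=O)O)[C@@H]2CC[C@H]1O2` gives 10000 nM
Compound 2 `O=C(O)c1ccc(NC(=O)C2C(C(=O)O)[C@@H]3CC[C@H]2O3)cc1Cl` gives 10000 nM
Compound 3 `O=C(O)C1C(C(=O)Nc2ccc(CO)cc2)[C@H]2CC[C@@H]1O2` gives 10000 nM

In an ADME assay on BE(2)-C cells (Homo sapiens) for cytotoxicity, read by MTT assay, with a stated time of 72 h (on this read-out higher numbers stand for weaker inhibition of growth and lower numbers for stronger inhibition of growth), compound 1 gives 10000 nM and stands level with compounds 2 and 3, within the scatter. Compound 4 `CCCCCCCCNC(=O)C1C(C(=O)O)[C@@H]2CC[C@H]1O2` keeps the core of compound 1 but carries a longer chain on the amide: butyl in place of hydrogen on a saturated chain carbon, four bonds along the chain from an amide-type nitrogen. Among the measured compounds shown here, no measured pair differs in one place only, so no direct step is available as a guide. Even so, compound 2 gives 10000 nM and compound 3 gives 10000 nM with quite different amide groups, so no step beyond the scatter is expected. The expected change is a 1.4-fold lower number from compound 1 to compound 4 (0.15 log units; within the scatter) and leans slightly toward stronger inhibition of growth. Compound 4 is estimated at 7000 nM with an expected range from 2500 nM to 20000 nM once measured.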

Compound 4, concentration for 50% growth inhibition: 10000 nM
Estimate against measurement, compound 4: 1.4-fold (0.15 log units) below; the range from low to high includes it.
By their numbers in this assay, from the lowest: compounds 1, 2, 3 and 4 (each within the scatter of the next).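

In this assay, among the compounds shown here, putting butyl in place of hydrogen on a saturated chain carbon, four bonds along the chain from an amide-type nitrogen, gives no change at the digits printed from compound 1 to compound 4 (within the scatter) and this is the first comparison of two compounds that differ in one place only. At this position, then, adding butyl leaves the growth-inhibition number where it stood. Nothing measured here offers an explanation for this result. From the compounds shown here alone, whether a still longer chain, or an amine in place of butyl, would shift the number remains open.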